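Biaryl extension on the sulfonyl arene of compound 1

The source may report more compounds than this note shows. Statements on the series, on what has been measured and on what is new or still open speak of the compounds shown alone.

The series shares a piperidinyl-piperidine sulfonamide core. Compound 1 `Cc1cccc(S(=O)(=O)N2CCC(N3CCC(C)CC3)CC2)c1` carries a 3-methylphenyl on the sulfonyl sulfur; in an ADME assay on HCT-116 cells (Homo sapiens) for cytotoxicity, read by CellTiter-Glo, with a stated time of 72 h (on this read-out higher numbers stand for weaker inhibition and lower numbers for stronger inhibition), compound 1 gives > 5000 nM, which is a limit of the assay and not a number. Compound 2 `CCc1ccc(S(=O)(=O)N2CCC(N3CCC(C)CC3)CC2)cc1` gives > 5000 nM in this assay, again a limit. Compound 3 `CC1CCN(C2CCN(S(=O)(=O)c3cn(C)cn3)CC2)CC1` gives > 10000 nM in this assay, also a limit. The measured steps a step that the two limits leave unreadable from compound 1 to compound 2, a step that the two limits leave unreadable from compound 1 to compound 3 and a step that the two limits leave unreadable from compound 2 to compound 3 therefore have no readable size, as the limit of > 5000 nM in this assay, at which 2 of the 3 values shown sit, and the limit of > 10000 nM in this assay, at which 1 of the 3 values shown sits, show; all three values sit at limits, so compound 1 cannot be ranked against compound 2 or compound 3.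

Compound 4 `Cc1ccc(-c2cccc(S(=O)(=O)N3CCC(N4CCC(C)CC4)CC3)c2)cc1` differs from compound 1 by 4-methylphenyl in place of methyl on an aromatic carbon. Among the compounds with values here, no measured step reads on this change, since every step is unreadable, and the only anchor is that compound 1 sits at a limit. The expected step is a step that the limit leaves unreadable from compound 1 to compound 4, with a limit the most likely outcome. Compound 4 is estimated at 8000 nM, within 2000 nM to 20000 nM.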

Compound 4, half-maximal inhibitory concentration: > 5000 nM
Compound 4: a limit, no number; the forecaster's own chance of this, stated with the estimate: 60%; the middle value lies beyond the limit too.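

In this assay compound 4 gives > 5000 nM, which is a limit and not a number. Compound 1 also sits at a limit, so no new step can be read between compound 1 and compound 4. The compounds shown leave open whether any group on the sulfonyl sulfur of the shared core gives a measurable value in this assay.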